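Chloro removal on the sulfonyl aryl of compound 3

A few compounds are considered here, and "the series" means these few. Any claim that something is new, unique, unknown or untested is made for them only; others in the source may bear on it.

Within the data shown here, the three compounds measured so far are compared in an assay on isolated protein for displacement of a labelled ligand from metabotropic glutamate receptor 5 (Homo sapiens), with a stated time of 60 min, tested at 1 uM; a lower number here means less inhibition, a higher number more inhibition at the concentration tested (going by the name of the read-out). Compound 1 `CC1CCN(c2c(S(=O)(=O)c3ccccc3)cnc3ccccc23)CC1` gives 89.2%. Compound 2 `Cc1ccc2ncc(S(=O)(=O)c3cccc(C#N)c3)c(N3CCC(C)CC3)c2c1` gives 52%, and compound 3 `Cc1ccc2ncc(S(=O)(=O)c3ccc(Cl)cc3)c(N3CCC(C)CC3)c2c1` gives 79%. Compound 3 stands second highest of the three numbers: compound 1 lies higher by a margin beyond the scatter, compound 2 lower by a larger margin, also beyond the scatter. Among the measured compounds shown here, the only single-point step in hand, a number 27 percentage points higher from compound 2 to compound 3 (beyond the scatter), concerns the aryl on the sulfonyl sulfur and shows that this ring can move the read-out by a modest amount.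

Compound 4 `Cc1ccc2ncc(S(=O)(=O)c3ccccc3)c(N3CCC(C)CC3)c2c1` differs from compound 3 by hydrogen in place of chloro on an aromatic carbon. For the measured compounds named here, no measured pair isolates the loss of a chloro alone; the step from compound 2 to compound 3 swaps two substituted rings and cannot be split into parts. Compound 1, which carries a phenyl on its sulfonyl sulfur, gives the highest value seen, so a phenyl there is compatible with strong inhibition. The expected step is therefore a number 1 percentage points higher from compound 3 to compound 4 (within the scatter), small and likely within the scatter. Compound 4 is estimated at 80%, with a range from 62% to 93%.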

Compound 4, a percentage reported as inhibition, at one concentration (the size of the read-out at that concentration, not a potency): 67%
The estimate for compound 4 lay 13 percentage points above the measured number; low and high end bracket the measured number.
By their numbers in this assay, from the lowest: compound 2; then compound 4; then compound 3; then compound 1.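

In this assay, the chloro now has a read of its own: a number 12 percentage points lower from compound 3 to compound 4 (beyond the scatter), so on this ring the 4-chlorophenyl group gives more inhibition than phenyl, while a number 15 percentage points higher from compound 2 to compound 4 (beyond the scatter) places phenyl above the 3-cyanophenyl compound, so substituents on this ring can move the number either way from the unsubstituted ring. The high value of compound 1 does not carry over to every phenyl sulfone, as a number 22.2 percentage points lower from compound 1 to compound 4 (beyond the scatter) shows that the methyl on the shared core also moves the read-out, here downward. No measurement at hand accounts for any of these shifts.

Open, as far as these compounds go, is whether the rise with chloro is specific to that atom or would also appear with a bromo, a methoxy or an amine at the same place. Also open, from the compounds shown here alone, is whether the chloro would raise the number on the core of compound 1, which lacks the methyl and already gives the highest value.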